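The source may report more compounds than this note shows. Statements on the series, on what has been measured and on what is new or still open speak of the compounds shown alone.

Measured so far in a physicochemical assay for solubility; on this read-out higher numbers stand for higher solubility and lower numbers for lower solubility:
- Compound 1 `CC(=O)SCCCCCCC(=O)Nc1ccccc1`: > 1000 ug/mL
- Compound 2 `CCOC(=O)SCCCCCCC(=O)Nc1ccccc1`: > 1000 ug/mL

Neither entry is an exact number. Compound 2 gives > 1000 ug/mL, which is a limit of the assay. Compound 1 also gives a limit, > 1000 ug/mL. Together they make up all the evidence so far: the limit of > 1000 ug/mL in this assay, at which 2 of the 2 values shown sit.

Compound 3 `CC(C)C(=O)SCCCCCCC(=O)Nc1ccccc1` has not yet been measured. It carries isopropyl in place of ethoxy on a carbonyl carbon whose other neighbour is sulfur: isopropyl in place of ethoxy on a carbonyl carbon.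

For the measured compounds named here, the one measured step that bears on this change falls on the same carbonyl carbon: a step that the two limits leave unreadable from compound 1 to compound 2. It offers no size to carry over and no direction to follow. With compound 2 reading > 1000 ug/mL, a limit, no step beyond the usual scatter is expected in this assay. The estimated step is a step that the limit leaves unreadable from compound 2 to compound 3. The expected solubility of compound 3 is 1200 ug/mL, with an estimated range of 500 ug/mL to 2500 ug/mL. The assay may well report only a limit once more.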

Compound 3, solubility: > 1000 ug/mL
Compound 3: no number, only a limit; the forecaster's own chance of this, stated with the estimate: 75%; the middle value is on the limit's open side.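

No step can be read between compound 1, compound 2 and compound 3, because each gives only a limit and not an exact number: the limit of > 1000 ug/mL in this assay, at which 3 of the 3 values shown sit.

The compounds shown leave open whether methyl, ethoxy and isopropyl on the carbonyl carbon differ at all in this assay.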